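Thiophene to difluorophenyl: expectation for compound 4

The source may report more compounds than this note shows. Statements on the series, on what has been measured and on what is new or still open speak of the compounds shown alone.

Compound 3 `CCn1c(=O)c2c(nc(Cc3cccs3)n2C)n(Cc2cccs2)c1=O` gives 95.5 nM in an assay on CHO cells for displacement of a labelled ligand from adenosine receptor A1 (Homo sapiens), read by scintillation counting (on this read-out higher numbers stand for weaker inhibition and lower numbers for stronger inhibition), the second highest of the three numbers shown. Compound 1 `CCCn1c(=O)c2[nH]c(-c3ccccc3)nc2n(CCSCC)c1=O` gives 93.3 nM, within the scatter of compound 3, while compound 2 `CCn1c(=O)c2c(nc(Cc3cccs3)n2C)n(Cc2ccccc2)c1=O` gives 389 nM, the highest. Compound 4 `CCn1c(=O)c2c(nc(Cc3c(F)cccc3F)n2C)n(Cc2cccs2)c1=O` differs from compound 3 by 2,6-difluorophenyl in place of thiophen-2-yl on a saturated chain carbon bound to an aromatic carbon. Going by the values given here, the only measured step, a 4.1-fold lower number from compound 2 to compound 3 (0.61 log units; beyond the scatter), sits on the other saturated chain carbon, the one bound to an aromatic nitrogen, and runs the opposite way, thiophen-2-yl entering for phenyl. If that pattern carries over, the number for compound 4 is expected to rise, though the two fluorines have no precedent here. Compound 4 is therefore estimated at 220 nM, between 70 nM and 700 nM. The expected step is a 2.3-fold higher number from compound 3 to compound 4 (0.36 log units; beyond the scatter).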

Compound 4, inhibition constant: 120 nM
The estimate for compound 4 lay 1.8-fold (0.26 log units) above the measured number; low and high end bracket the measured number.
By their numbers in this assay, from the lowest: compounds 1, 3 and 4 (each within the scatter of the next); then compound 2.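

The change at this place brings a 1.3-fold higher number from compound 3 to compound 4 (0.10 log units; within the scatter) in this assay, so on a saturated chain carbon bound to an aromatic carbon, the read-out does not separate thiophen-2-yl from 2,6-difluorophenyl. This differs from the other saturated chain carbon, bound to an aromatic nitrogen, where a 4.1-fold lower number from compound 2 to compound 3 (0.61 log units; beyond the scatter) is beyond the scatter. Nothing available explains why the two places differ.

As far as these compounds go, whether a plain phenyl at this place would give a similar number stays open, and so does the outcome for a ring carrying an amine or a carboxylic acid.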